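Benzamidomethyl on the cyclohexyl ring of compound 2

This account rests on a few compounds, and the source may have more. Where it says the series, first, only, none or still open, it means among the compounds named here.

The series shares a fluoro-bromo-anilino oxime ketone core carried on a six-membered saturated ring. In an assay for inhibition of Indoleamine 2,3-dioxygenase 1 (Homo sapiens), with a stated time of 1 h (on this read-out lower numbers stand for stronger inhibition and higher numbers for weaker inhibition), compound 1 `NS(=O)(=O)N1CCC(C(=O)/C(=N/O)Nc2ccc(F)c(Br)c2)CC1` gives 63 nM. In this assay compound 2 `O=C(/C(=N/O)Nc1ccc(F)c(Br)c1)C1CCCCC1` gives 132 nM, the higher of the two numbers recorded so far, and the gap to compound 1 is beyond the usual scatter.

Compound 3 `O=C(NC[C@H]1CC[C@H](C(=O)/C(=N/O)Nc2ccc(F)c(Br)c2)CC1)c1ccccc1` has not yet been measured. Relative to compound 2 it carries benzamidomethyl in place of hydrogen on a saturated ring carbon, so the saturated ring of compound 2 now bears a second large group. Going by the values given here, no measured pair in the set isolates this change, and compound 1 differs from compound 2 in the ring itself rather than at this position, so the step from compound 2 to compound 3 can only be guessed. A modest lowering of the number is expected, of a size that may not exceed the scatter, since the added group is well separated from the oxime ketone portion. Compound 3 is therefore estimated at 80 nM in this assay, with a range of 25 nM to 300 nM, which corresponds to an expected step of a 1.7-fold lower number from compound 2 to compound 3 (0.22 log units; within the scatter).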

Compound 3, half-maximal inhibitory concentration: 80 nM
Estimate against measurement, compound 3: no gap at the digits printed; low and high end bracket the measured number.
By their numbers in this assay, from the lowest: compounds 1, 3 and 2 (each within the scatter of the next, the first and the last beyond it).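

In this assay, benzamidomethyl in place of hydrogen on a saturated ring carbon, three ring bonds from the ring atom that bears a large group, gives a 1.7-fold lower number from compound 2 to compound 3 (0.22 log units; within the scatter). Going by these compounds alone, this is the first reading at this position, and it shows that the six-membered non-aromatic ring of carbon only can carry this second large group, with its six-membered aromatic ring and amide, while compound 3 stays within the scatter of compound 2 on this read-out. Nothing in hand explains why the group leaves the number within the scatter, and the data give no measured property of the group or the change that could be linked to this result.

With a single substituent at this carbon, the compounds shown give no trend in the size or kind of group tolerated there. Going by these compounds, how an aminomethyl group, a carboxylic acid or a longer chain ending in a phenyl ring would read at this carbon remains open, as do the contributions of the carbonyl and the amide hydrogen of the benzamide and the effect of the other stereochemical arrangement of the two ring substituents.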